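Removal of the N-benzyl group in a nitroquinolinone series

The source may hold more compounds than are shown below. What is called first, only, known or untested is meant among the compounds shown, and "the series" means these compounds.

Measured compounds:
compound 1, `COc1ccc(Cn2c(-c3ccc(C)cc3)c(Br)c(=O)c3cc([N+](=O)[O-])ccc32)cc1`: 2430 nM
compound 2, `CCc1ccc(-c2c(-c3ccc(C)cc3)n(Cc3ccc(OC)cc3)c3ccc([N+](=O)[O-])cc3c2=O)cc1`: 5750 nM

In an assay on isolated protein for inhibition of Intestinal-type alkaline phosphatase (Bos taurus), read by spectrophotometry, with stated times of 7 min and 15 min (on this read-out higher numbers stand for weaker inhibition and lower numbers for stronger inhibition), compound 1 gives 2430 nM, the lowest of the two numbers shown; the only other measured compound, compound 2, stands a 2.4-fold higher number from compound 1 to compound 2 (0.37 log units; beyond the scatter), a step that places 4-ethylphenyl in place of bromo and leaves the rest of the shared core untouched.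

Compound 3, `Cc1ccc(-c2[nH]c3ccc([N+](=O)[O-])cc3c(=O)c2Br)cc1`, is not yet measured. It differs from compound 1 by hydrogen in place of 4-methoxybenzyl on an aromatic nitrogen. Among the compounds with values here, no measured step touches this aromatic nitrogen; the one step on record, the change from compound 1 to compound 2, concerns a different position and was modest, so it offers no guide to the direction or size here. The expectation therefore rests on compound 1 alone, with a wide range: for compound 3 in this assay the estimate is 3500 nM (range 800 nM to 15000 nM), corresponding to an expected step of a 1.4-fold higher number from compound 1 to compound 3 (0.16 log units; within the scatter).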

Compound 3, half-maximal inhibitory concentration: 12100 nM
The estimate for compound 3 lay 3.5-fold (0.54 log units) below the measured number; the measured number falls inside the stated range.
By their numbers in this assay, from the lowest: compound 1; then compound 2; then compound 3.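

In this assay, within the data shown here, hydrogen in place of 4-methoxybenzyl on the aromatic nitrogen gives a 5.0-fold higher number from compound 1 to compound 3 (0.70 log units; beyond the scatter), the first reading at this position, and it shows that the lower number in this pair goes with the substituted nitrogen. Set beside a 2.4-fold higher number from compound 1 to compound 2 (0.37 log units; beyond the scatter), the change at the nitrogen prints the larger step of the two on record, though both are classed as modest. The data at hand offer nothing that explains this step.

As far as these compounds go, it remains open whether the lower number depends on the six-membered aromatic ring, on its methoxy group or simply on having any substituent at the nitrogen, a question that an unsubstituted benzyl, a methyl or a longer alkyl chain there would address. Also open, from the compounds shown here alone, is whether the step at the nitrogen keeps its direction and size when 4-ethylphenyl stands in place of bromo.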